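The source may report more compounds than this note shows. Statements on the series, on what has been measured and on what is new or still open speak of the compounds shown alone.

Of the compounds shown here, two have so far been measured in an assay on isolated protein for inhibition of Rho-associated protein kinase 2 (Homo sapiens), read by radiometric assay; a higher number here means a weaker inhibitor, a lower number a stronger inhibitor. Compound 1 `NCc1ccc(C(=O)Nc2ccncc2)cc1-c1cccc(C(=O)OCC2CCCCC2)c1` gives 48 nM in this assay. Compound 2 `CC(C)OCCOC(=O)c1cccc(-c2cc(C(=O)Nc3ccncc3F)ccc2CN)c1` gives 37 nM in this assay. Compound 1 has the higher of the two numbers, but its gap to compound 2 lies within the scatter of repeated measurements, so the two cannot be told apart on these data.

Compound 3 `CCCCCOC(=O)c1cccc(-c2cc(C(=O)Nc3ccncc3)ccc2CN)c1` has not yet been measured. It differs from compound 1 in a single place: butyl in place of cyclohexyl on a saturated chain carbon bound to an oxygen next to a carbonyl group. The ester itself stays; a ring on a saturated chain carbon bound to an oxygen next to a carbonyl group is exchanged for an open chain of similar size.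

Within the data shown here, no measured pair shows this exact exchange, so its effect has not been observed. Since the change is small and sits far from the amide and the amine that the two measured compounds share, a step no larger than the scatter is expected in this assay, in either direction. The estimate for compound 3 is 60 nM, with a range from 25 nM to 150 nM. This corresponds to an expected step of a 1.3-fold higher number from compound 1 to compound 3 (0.10 log units; within the scatter).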

Compound 3, half-maximal inhibitory concentration: 4.9 nM
For compound 3 the middle estimate is 12-fold (1.09 log units) above the measured one, and the stated range ends above it.
By their numbers in this assay, from the lowest: compound 3; then compounds 2 and 1 (each within the scatter of the next).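

In this assay, replacing cyclohexyl with butyl on a saturated chain carbon bound to an oxygen next to a carbonyl group gives a 9.8-fold lower number from compound 1 to compound 3 (0.99 log units; beyond the scatter), a change larger than repeated measurements would produce by chance. This shows that the group at this position affects the inhibition read-out, and that here the open chain, with fewer heavy atoms and no ring, goes with the lower number. Among these compounds, with only this one pair, the effect of opening the ring cannot be separated from that of changing the group's size, and no measurement available here explains the step.

On these data alone, it remains open whether the trend continues with a longer chain such as hexyl, or whether a smaller ring such as cyclopentyl would match the open chain. As far as these compounds go, how far this position tolerates other kinds of group, such as an amine or a carboxylic acid at the end of the chain, and whether the same exchange gives a similar step on a different amide, also remain unknown.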